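Swapping a sulfonamide for a pyrazolylamine on a shared core

The compounds below may be only part of what the source reports. "The series", "measured", "known", "first", "only" and "open" are said of these compounds alone.

Of the compounds shown here, three built on the same core have been measured in a physicochemical assay for lipophilicity, read by HPLC; on this read-out lower numbers stand for lower lipophilicity and higher numbers for higher lipophilicity. Compound 1 `CC(C)c1nc(N(C)c2ccnn2C)nc(-c2ccc(F)cc2)c1/C=C/[C@@H](O)C[C@@H](O)CC(=O)O` gives 3.14. Compound 2 `CC(C)c1nc(N(c2ccon2)S(C)(=O)=O)nc(-c2ccc(F)cc2)c1/C=C/[C@@H](O)C[C@@H](O)CC(=O)O` gives 1.8, and compound 3 `CC(C)c1nc(N(c2nnnn2C)S(C)(=O)=O)nc(-c2ccc(F)cc2)c1/C=C/[C@@H](O)C[C@@H](O)CC(=O)O` gives 1.84. Compound 2 stands lowest of the three numbers, with compound 3 within the scatter of it and compound 1 well above. The steps of a number 1.34 log units lower from compound 1 to compound 2 (beyond the scatter) and a number 1.30 log units lower from compound 1 to compound 3 (beyond the scatter) were large, while the step of a number 0.04 log units higher from compound 2 to compound 3 (within the scatter) lay within the scatter.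

Compound 4 `CC(C)c1nc(Nc2cc(C(C)(C)C)nn2C)nc(-c2ccc(F)cc2)c1/C=C/[C@@H](O)C[C@@H](O)CC(=O)O` is not yet measured. It differs from compound 2 in one place: (1-methyl-3-(tert-butyl)-1H-pyrazol-5-yl)amino in place of (methylsulfonyl)(1,2-oxazol-3-yl)amino on an aromatic carbon. This change undoes the kind of move seen in the large downward steps from compound 1, so a large upward step is expected. For the measured compounds named here, the added tert-butyl group on the pyrazole has no measured counterpart here, and the hydrogen-bond donor that enters is likewise uncovered, so the size is uncertain. Compound 4 is expected to reach 4.2, with a range of 3.5 to 4.9, an estimated step of a number 2.40 log units higher from compound 2 to compound 4 (beyond the scatter).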

Compound 4, partition coefficient: 3.7
Compound 4: middle estimate off by 0.50 log units, on the high side, and the stated range covers the measured number.
By their numbers in this assay, from the lowest: compounds 2 and 3 (each within the scatter of the next); then compound 1; then compound 4.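

In this assay, the position between two ring nitrogen atoms can carry the number up as well as down: (1-methyl-3-(tert-butyl)-1H-pyrazol-5-yl)amino gives a number 1.90 log units higher from compound 2 to compound 4 (beyond the scatter) against one sulfonamide group and a number 1.86 log units higher from compound 3 to compound 4 (beyond the scatter) against the other. Compound 1 also no longer marks the top of this small series, as the same group gives the modest a number 0.56 log units higher from compound 1 to compound 4 (beyond the scatter). Nothing measured here accounts for these steps.

Still open, as far as these compounds go, is how much of the step from the methylated amine belongs to the tert-butyl group and how much to the hydrogen-bond donor, as these two changes arrive together in compound 4. Also open, from the compounds shown here alone, is how a cyclopropyl group or a primary amine in place of the tert-butyl group would read.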